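A few compounds are considered here, and "the series" means these few. Any claim that something is new, unique, unknown or untested is made for them only; others in the source may bear on it.

Measured so far in a functional assay on HepG2 cells (Homo sapiens) for inhibition, read by MTT assay, with a stated time of 72 h; on this read-out higher numbers stand for weaker inhibition and lower numbers for stronger inhibition:

Compound 1, `C#CCSc1nc(Nc2ccccc2)c2ccncc2n1`, gives 29400 nM.
Compound 2, `C#CCSc1nc(N2CCN(C)CC2)c2ccncc2n1`, gives only a limit of the assay, > 80000 nM.
Compound 3, `C#CCSc1nc(N2CCN(CC)CC2)c2ccncc2n1`, likewise gives only a limit of the assay, > 80000 nM.

Compound 3 therefore stands at the edge of what this assay can report, with no number of its own; it shares this with compound 2, as the limit of > 80000 nM in this assay, at which 2 of the 3 values shown sit, shows. Two measured steps surround it. The first, an at least 2.7-fold higher number from compound 1 to compound 2 (0.43 log units; beyond the scatter), is a shift away from an anilino group toward a ring amine. The second, a step that the two limits leave unreadable from compound 2 to compound 3, cannot be sized, since both compounds sit at the limit.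

Compound 4, `C#CCSc1nc(N2CCN(C(=O)OC(C)(C)C)CC2)c2ccncc2n1`, differs from compound 3 by tert-butoxycarbonyl in place of ethyl on an amine nitrogen in a ring. Neither measured step tells how a tert-butoxycarbonyl group on that ring nitrogen will behave, and compound 3 itself has no readable number to move from. The step from compound 3 to compound 4 is therefore expected to be a step that the limit leaves unreadable from compound 3 to compound 4, that is, nothing beyond the scatter. Compound 4 is estimated to give 100000 nM, in a range from 30000 nM to 300000 nM, most likely again only as a limit.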

Compound 4, half-maximal inhibitory concentration: 55900 nM
Compound 4: the middle estimate sits 1.8-fold (0.25 log units) above what was measured; the range from low to high includes it.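

Of the compounds carrying a group on this ring nitrogen, only compound 4 gives a number of its own in this assay, while compound 2 and compound 3 stop at a limit: the limit of > 80000 nM in this assay, at which 2 of the 4 values shown sit.

The two new steps, an at least 1.4-fold lower number from compound 3 to compound 4 (0.15 log units; that floor lies within the scatter) and an at least 1.4-fold lower number from compound 2 to compound 4 (0.15 log units; that floor lies within the scatter), are only floors, so the true gaps could be larger, but neither is shown to go beyond the scatter. What is new is that a tert-butoxycarbonyl group, with 7 heavy atoms against 2 for ethyl, can sit on this nitrogen and still leave a readable inhibition.

An acetyl group or a benzyl group on this nitrogen would help tell whether the carbonyl or the tert-butyl end goes with that reading. Also open, on these data alone, is whether the free ring amine, with hydrogen on this nitrogen, behaves like compound 2 or like compound 4.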